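Acetyl Added to the Phenyl of Compound 2

The compounds below may be only part of what the source reports. "The series", "measured", "known", "first", "only" and "open" are said of these compounds alone.

Compound 1 `COc1cc(-c2cc3nccc(-c4cc(OC)c(OC)c(OC)c4)n3n2)cc(OC)c1OC`: in a functional assay on HeLa cells (Homo sapiens) for inhibition, read by CCK-8 assay, with a stated time of 48 h (on this read-out higher numbers stand for weaker inhibition and lower numbers for stronger inhibition), compound 1 gives > 10000 nM, which is a limit of the assay and not a number.
Compound 2 `COc1cc(-c2ccnc3cc(-c4ccccc4)nn23)cc(OC)c1OC`: in this assay compound 2 gives 458 nM.

Compound 2 stands as the only number shown; the other value is a limit (the limit of > 10000 nM in this assay, at which 1 of the 2 values shown sits). Compound 3 `COc1cc(-c2ccnc3cc(-c4ccc(C(C)=O)cc4)nn23)cc(OC)c1OC` has not yet been measured. It differs from compound 2 in one place: acetyl in place of hydrogen on an aromatic carbon. Cut one bond further out, the change reads phenyl to 4-acetylphenyl. Going by the values given here, no step between two measured compounds is available, so the size of this change in this assay can only be expected, not read off. The expectation is a step within or close to the usual scatter, in either direction, a 1.0-fold lower number from compound 2 to compound 3 (0.01 log units; within the scatter). Compound 3 is therefore estimated at 450 nM, with a range from 120 nM to 1800 nM.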

Compound 3, half-maximal inhibitory concentration: 1810 nM
Beside the measured number, compound 3's estimate is 4.0-fold (0.60 log units) below it; measured number above the stated range.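

In this assay the phenyl of compound 2 proves sensitive to substitution: acetyl in place of hydrogen, para to a large group, gives a 4.0-fold higher number from compound 2 to compound 3 (0.60 log units; beyond the scatter) and so weaker inhibition. Going by these compounds alone, this is the first step that can be read on this ring, and it lies beyond the usual scatter while remaining modest in size. The change lowers inhibition without removing it, since compound 3 still gives a measured number and not a limit.

Still open, going by these compounds, is whether any group at this place would cost inhibition or whether the loss is particular to acetyl, as an amine or a carboxylic acid on the same carbon could show. Nothing shown here gives a reason for the step.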